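Trimming One Methoxy Group from the Aryl Ketone

The source may hold more compounds than are shown below. What is called first, only, known or untested is meant among the compounds shown, and "the series" means these compounds.

Compound 1, `COc1cc(-c2cc(/C=C/C(=O)c3ccc(N)cc3)[nH]n2)cc(OC)c1OC`: 1860 nM
Compound 2, `COc1cc(-c2cc(/C=C/C(=O)c3ccc(Cl)c(Cl)c3)[nH]n2)cc(OC)c1OC`: 18500 nM
Compound 3, `COc1ccc(C(=O)/C=C/c2cc(-c3cc(OC)c(OC)c(OC)c3)n[nH]2)cc1OC`: 1780 nM

In a functional assay on SK-MEL-28 cells (Homo sapiens) for inhibition, read by sulforhodamine B assay, with a stated time of 48 h (a lower number here means a stronger inhibitor of growth, a higher number a weaker inhibitor of growth), compound 1 gives 1860 nM, compound 2 gives 18500 nM and compound 3 gives 1780 nM. Compound 3 has the lowest number of the three, but compound 1 sits within the scatter of it, so the two cannot be ranked; only compound 2 stands clearly apart, as a 10-fold lower number from compound 2 to compound 3 (1.02 log units; beyond the scatter) shows. Compound 4, `COc1ccc(C(=O)/C=C/c2cc(-c3cc(OC)c(OC)c(OC)c3)n[nH]2)cc1`, differs from compound 3 in one place: hydrogen in place of methoxy on an aromatic carbon. For the measured compounds named here, no measured step removes a single group from this ring; the steps that touch it, a 1.0-fold lower number from compound 1 to compound 3 (0.02 log units; within the scatter) and a 10-fold lower number from compound 2 to compound 3 (1.02 log units; beyond the scatter), replace the whole ring, and they show that this ring can leave the number almost unchanged or shift it strongly. Since one methoxy group remains in place, only a small step is expected, a 1.4-fold higher number from compound 3 to compound 4 (0.15 log units; within the scatter), if anything toward a slightly higher number. Compound 4 is therefore estimated at 2500 nM, with a range from 900 nM to 8000 nM.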

Compound 4, concentration for 50% growth inhibition: 2120 nM
Compound 4: middle estimate off by 1.2-fold (0.07 log units), on the high side; the measured number falls inside the stated range.
By their numbers in this assay, from the lowest: compounds 3, 1 and 4 (each within the scatter of the next); then compound 2.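

Taking a single methoxy group off the 3,4-dimethoxyphenyl ring, rather than replacing the whole ring, leaves the result in this assay within the scatter (a 1.2-fold higher number from compound 3 to compound 4 (0.08 log units; within the scatter)), so the 3,4-dimethoxyphenyl and 4-methoxyphenyl rings cannot be told apart here. Methoxy in place of amino on the same ring also stays within the scatter (a 1.1-fold higher number from compound 1 to compound 4 (0.06 log units; within the scatter)), whereas the 4-methoxyphenyl ring stands clearly apart from the 3,4-dichlorophenyl ring (an 8.7-fold lower number from compound 2 to compound 4 (0.94 log units; beyond the scatter)). No measurement at hand explains why these rings differ or match.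

The compounds shown leave open whether the remaining methoxy group matters at all, as they include no unsubstituted phenyl ring. They also do not show how a hydroxy group or a longer chain such as ethoxy would behave at this place.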